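Acetyl in Place of Methyl on an Aromatic Oxygen

The source may hold more compounds than are shown below. What is called first, only, known or untested is meant among the compounds shown, and "the series" means these compounds.

Compound 1 `CCOC1=CC(=O)c2ccccc2C1=O`: 23800 nM in a functional assay on HeLa cells (Homo sapiens) for cytotoxicity; a higher number here means a weaker inhibitor, a lower number a stronger inhibitor
Compound 2 `O=C(Oc1ccc2c(c1)C(=O)C=CC2=O)c1ccccc1`: 19200 nM in this assay
Compound 3 `COc1ccc2c(c1)C(=O)C=CC2=O`: 22700 nM in this assay

Of the compounds shown here, three have numbers in this assay so far. Compound 3 differs from compound 1 and from compound 2 by less than the usual scatter of repeated measurements, so the three numbers cannot be told apart. Compound 4 `CC(=O)Oc1ccc2c(c1)C(=O)C=CC2=O` has not yet been measured. It differs from compound 3 in one place: acetyl in place of methyl on an oxygen on an aromatic ring. Compound 2 also carries an ester on an oxygen on an aromatic ring, and compound 2 gives 19200 nM, which lies within the scatter of the number for compound 3. No step beyond the scatter is therefore expected from compound 3 to compound 4; the expected step is a 1.1-fold lower number from compound 3 to compound 4 (0.03 log units; within the scatter). Compound 4 is estimated at 21000 nM, with a range from 10000 nM to 45000 nM.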

Compound 4, half-maximal inhibitory concentration: 27700 nM
For compound 4 the middle estimate is 1.3-fold (0.12 log units) below the measured one; the range from low to high includes it.
By their numbers in this assay, from the lowest: compounds 2, 3, 1 and 4 (each within the scatter of the next).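

Placing acetyl instead of methyl on the oxygen on the aromatic ring gives a 1.2-fold higher number from compound 3 to compound 4 (0.09 log units; within the scatter) in this assay. Within the esters, methyl in place of phenyl on the carbonyl carbon gives a 1.4-fold higher number from compound 2 to compound 4 (0.16 log units; within the scatter), so neither the methoxy-to-acetoxy swap nor the size of the ester group separates these compounds in this assay. No measurement shown offers an explanation for this. On these data alone, it remains open whether a free hydroxyl, an amine or a longer chain at this oxygen would give a number beyond the scatter.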